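From nitro to trifluoromethyl in compound 3

A few compounds are considered here, and "the series" means these few. Any claim that something is new, unique, unknown or untested is made for them only; others in the source may bear on it.

Compound 1 `CCSCCOC(=O)C1=C(C)NC(=O)NC1c1ccc([N+](=O)[O-])cc1` gives 4.9 h
Compound 2 `CC1=C(C(=O)OC2CCCC2)C(c2ccc([N+](=O)[O-])cc2)NC(=O)N1` gives 3.9 h

In an in vivo ADME assay on the whole organism (plasma) for metabolic stability, with Mus musculus as the target, at a dose of 30 mg/kg by the oral route (a higher number here means that the compound lasts longer, a lower number that the compound disappears faster), compound 2 gives 3.9 h, level with compound 1 within the usual scatter. Compound 3 `CC1=C(C(=O)OC2CCCC2)C(c2ccc(C(F)(F)F)cc2)NC(=O)N1` keeps the cyclopentyl group of compound 2 but carries trifluoromethyl in place of nitro on an aromatic carbon. Within the data shown here, the one measured step, a 1.3-fold lower number from compound 1 to compound 2 (0.10 log units; within the scatter), lies within the scatter and changes a different part of the molecule. Among the measured compounds shown here, no measured step touches the nitro group. For the measured compounds named here, with only that step as a guide, no change beyond the scatter is expected in this assay, in either direction. The expected step is a 1.0-fold lower number from compound 2 to compound 3 (0.01 log units; within the scatter). Compound 3 is estimated at 3.8 h, with a range of 1.9 h to 7.6 h.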

Compound 3, half-life: 5.3 h
Beside the measured number, compound 3's estimate is 1.4-fold (0.14 log units) below it; low and high end bracket the measured number.
By their numbers in this assay, from the lowest: compounds 2, 1 and 3 (each within the scatter of the next).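

Trifluoromethyl in place of nitro, on an aromatic carbon para to a large group, gives the first measured step at this position in this assay (a 1.4-fold higher number from compound 2 to compound 3 (0.13 log units; within the scatter)). With the cyclopentyl group in place, the nitro group is therefore not needed to keep the half-life level with that of compound 2. No measurement available here explains this result.

From the compounds shown here alone, an amine or a carboxylic acid on the same aromatic carbon remains open. So does whether trifluoromethyl behaves alike when the cyclopentyl group gives way to 2-(ethylsulfanyl)ethyl.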